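Losing the phenyl on the amide-type nitrogen

This account rests on a few compounds, and the source may have more. Where it says the series, first, only, none or still open, it means among the compounds named here.

Measured in a functional assay on KB cells (Homo sapiens) for antiproliferative activity, read by MTT assay, with a stated time of 48 h; a lower number here means a stronger inhibitor, a higher number a weaker inhibitor:
Compound 1 `Cn1cc(C2=C(c3nn(CCCn4ccnc4)c4ncccc34)C(=O)NC2=O)c2ccccc21`: > 100000 nM (a limit of the assay)
Compound 2 `CN1CCN(CCCn2nc(C3=C(c4cn(C)c5ccccc45)C(=O)NC3=O)c3cccnc32)CC1`: > 100000 nM (a limit of the assay)
Compound 3 `CN(C)CCCn1nc(C2=C(c3cn(C)c4ccccc34)C(=O)N(c3ccccc3)C2=O)c2cccnc21`: 14100 nM

In this assay, going by the values given here, compound 3, at 14100 nM, holds the only true number of the series. The other two results are limits rather than numbers, and they stand at the limit of > 100000 nM in this assay, at which 2 of the 3 values shown sit.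

The next compound, compound 4 `CN(C)CCCn1nc(C2=C(c3cn(C)c4ccccc34)C(=O)NC2=O)c2cccnc21`, departs from compound 3 at a single place: hydrogen in place of phenyl on an amide-type nitrogen in a ring.

Among the compounds with values here, the one measured step gives no size to work from. It is a step that the two limits leave unreadable from compound 1 to compound 2, and it concerns the end of the chain, not this nitrogen. The closest guidance comes from the values themselves. Compound 1 also carries hydrogen on that nitrogen and stays at the limit > 100000 nM. Compound 2 carries it too and stays at the limit > 100000 nM. Within the data shown here, a weakening is therefore expected, though its size is uncertain, since no measured step covers this nitrogen. The expected change is a 2.8-fold higher number from compound 3 to compound 4 (0.45 log units; beyond the scatter), and the result may well be reported only as a limit. For compound 4 the estimate is 40000 nM, with an expected range of 8000 nM to 100000 nM.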

Compound 4, half-maximal inhibitory concentration: > 100000 nM
Compound 4: a limit, no number; the forecaster's own chance of this, stated with the estimate: 45%; at least 2.5-fold (0.39 log units) between middle value and limit.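

In this assay, going by these compounds alone, taking the phenyl off the amide-type nitrogen gives an at least 7.0-fold higher number from compound 3 to compound 4 (0.85 log units; beyond the scatter), the first step that can be read and the first to concern this nitrogen. One end of that step is a limit, which means the printed size is a lower bound and the real change may be larger. With the dimethylamino chain held the same, the step shows that the phenyl on this nitrogen matters by itself, something compound 1 and compound 2 could not show, and the steps among compound 1, compound 2 and compound 4 cannot be read: the limit of > 100000 nM in this assay, at which 3 of the 4 values shown sit.

As far as these compounds go, it remains open whether the phenyl ring itself is needed on this nitrogen, or whether a methyl, a benzyl or a 4-fluorophenyl group there would hold the value of compound 3 or lose it. From the compounds shown here alone, it is equally open how the chain ends 1H-imidazol-1-yl and 4-methylpiperazin-1-yl, or a morpholine at the same place, would read once a phenyl sits on the nitrogen.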